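The compounds below may be only part of what the source reports. "The series", "measured", "known", "first", "only" and "open" are said of these compounds alone.

Measured so far:
compound 1 `COC(=O)c1sc2c(C)cccc2c1Nc1cc(OC)c(OC)c(OC)c1`: 4550 nM
compound 2 `CCOC(=O)c1sc2cc(C)ccc2c1Nc1cc(OC)c(OC)c(OC)c1`: 9 nM

In a functional assay on MCF7 cells (Homo sapiens) for cytotoxicity, read by MTT assay, with a stated time of 72 h (a higher number here means a weaker inhibitor, a lower number a stronger inhibitor), compound 1 gives 4550 nM, the higher of the two numbers and so the weaker inhibitor, well beyond the usual scatter. Compound 2 gives 9 nM, but it differs from compound 1 in more than one place, so this gap cannot be tied to any single change.

Compound 3 `COC(=O)c1sc2ccccc2c1Nc1cc(OC)c(OC)c(OC)c1` has hydrogen in place of methyl on an aromatic carbon of compound 1 (hydrogen in place of methyl on an aromatic carbon). With compound 2 at 9 nM, this family can clearly reach much lower numbers than compound 1, so a clear move towards stronger inhibition seems likely, though not the whole gap. The expected change is a 9.1-fold lower number from compound 1 to compound 3 (0.96 log units; beyond the scatter), a step beyond the scatter. For compound 3 the estimated value is 500 nM, with an expected range from 60 nM to 4000 nM.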

Compound 3, half-maximal inhibitory concentration: 795 nM
Compound 3: middle estimate off by 1.6-fold (0.20 log units), on the low side; the measured number falls inside the stated range.
By their numbers in this assay, from the lowest: compound 2; then compound 3; then compound 1.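

In this assay replacing methyl with hydrogen on this aromatic carbon, ortho to a fused ring and meta to a fused ring, gives a 5.7-fold lower number from compound 1 to compound 3 (0.76 log units; beyond the scatter). Going by these compounds alone, this is the first step that can be tied to a single change, and it shows that the methyl at this place goes with weaker inhibition on the core of compound 1. The data offer nothing that explains this difference.

Compound 2 differs from compound 1 and compound 3 in more than one place, so its steps to them cannot be read, and the effect of a methyl elsewhere on this ring stays unsettled. Also open, going by these compounds, is how a fluorine, a methoxy group or a longer chain such as ethyl on this same carbon would compare with hydrogen and methyl.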